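Swapping a Thiazole for a Pyrrole on the Shared Core

A few compounds are considered here, and "the series" means these few. Any claim that something is new, unique, unknown or untested is made for them only; others in the source may bear on it.

Among the compounds with values here, in a functional assay on A-375 cells (Homo sapiens) for antiproliferative activity (on this read-out lower numbers stand for stronger inhibition and higher numbers for weaker inhibition), compound 1 `O=C(Nc1ccc(-c2cscn2)cc1)C1CCCN(Cc2ccc(F)c(F)c2)C1` gives 880 nM, the lowest of the two numbers known so far. Within the data shown here, compound 2 `O=C(Nc1ccc(-c2cscn2)cc1)C1CCCN(Cc2ccccc2F)C1` gives 4000 nM, and the one measured step, a 4.5-fold higher number from compound 1 to compound 2 (0.66 log units; beyond the scatter), concerns a different part of the molecule. Compound 3 `O=C(Nc1ccc(-c2cc[nH]c2)cc1)C1CCCN(Cc2ccc(F)c(F)c2)C1` differs from compound 1 by 1H-pyrrol-3-yl in place of 1,3-thiazol-4-yl on an aromatic carbon. Among the measured compounds shown here, no measured step touches this ring, so the direction of change is open. Compound 3 is therefore expected to give about 1500 nM, within 300 nM to 8000 nM. That estimate amounts to an expected step of a 1.7-fold higher number from compound 1 to compound 3 (0.23 log units; within the scatter).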

Compound 3, half-maximal inhibitory concentration: 1420 nM
The estimate for compound 3 lay 1.1-fold (0.02 log units) above the measured number; the measured number falls inside the stated range.
By their numbers in this assay, from the lowest: compounds 1 and 3 (each within the scatter of the next); then compound 2.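

In this assay, placing 1H-pyrrol-3-yl on this aromatic carbon instead of 1,3-thiazol-4-yl gives a 1.6-fold higher number from compound 1 to compound 3 (0.21 log units; within the scatter) and so leaves the two compounds indistinguishable. This position therefore accepts both rings, even though they differ in their hetero atoms and in their hydrogen-bond donors and acceptors. No measurement available here bears on the reason for this result. Going by these compounds, whether a pyridine ring or a carboxylic acid at this position would give a similar number remains open. Also open, on these data alone, is whether the same ring exchange would behave alike alongside the 2-fluorophenyl group of compound 2.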